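A few compounds are considered here, and "the series" means these few. Any claim that something is new, unique, unknown or untested is made for them only; others in the source may bear on it.

Three close relatives of one shared core have been measured in a physicochemical assay for solubility, in phosphate buffer, with a stated time of 18 h; on this read-out higher numbers stand for higher solubility and lower numbers for lower solubility. Compound 1 `CC(C)(C)c1ncc2c(N)c(C#N)c(N)nc2n1` gives 37200 nM. Compound 2 `CSc1nc(C(C)(C)C)nc2nc(N)c(C#N)c(N)c12` gives 14000 nM, and compound 3 `CCCCc1nc(C(C)(C)C)nc2nc(N)c(C#N)c(N)c12` gives 6000 nM. Compound 3 therefore stands lowest of the three, with compound 2 nearest and compound 1 furthest from it; the steps were a 2.7-fold lower number from compound 1 to compound 2 (0.42 log units; beyond the scatter), a 6.2-fold lower number from compound 1 to compound 3 (0.79 log units; beyond the scatter) and a 2.3-fold lower number from compound 2 to compound 3 (0.37 log units; beyond the scatter), each modest but beyond the scatter.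

The unmeasured compound 4 `CC(C)(C)c1nc(C2CCCC2)c2c(N)c(C#N)c(N)nc2n1` differs from compound 3 in one place: cyclopentyl in place of butyl on an aromatic carbon. Among the compounds with values here, no measured pair exchanges one carbon-only group for another of this kind, so the step cannot be read off directly. What the data do show is that placing a group on this aromatic carbon lowered the number in each measured case, and that the larger group, butyl, lay lowest. Cyclopentyl is of similar size and composition, one heavy atom more and closed into a ring, so a step near zero or slightly downward, within or only just beyond the scatter, is expected in this assay.

Compound 4 is thus expected to give 4500 nM, in a range from 1800 nM to 11000 nM. That estimate means a step of a 1.3-fold lower number from compound 3 to compound 4 (0.12 log units; within the scatter).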

Compound 4, solubility: < 1000 nM
Compound 4 ended at the assay's limit (the forecaster's own chance of this, stated with the estimate: 5%); middle value at least 4.5-fold (0.65 log units) from the limit.
By their numbers in this assay, from the lowest: compound 3; then compound 2; then compound 1. At a limit, below all of these: compound 4.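

In this assay compound 4 gives no number, only a limit of the assay: the limit of < 1000 nM in this assay, at which 1 of the 4 values shown sits. Even so, the exchange of one carbon-only group for another on this aromatic carbon, next to the ring nitrogen, proves to matter, with an at least 6.0-fold lower number from compound 3 to compound 4 (0.77 log units; beyond the scatter), whereas the earlier compounds showed only modest steps among hydrogen, methylsulfanyl and butyl. Against those two other groups the change is large, with an at least 14-fold lower number from compound 2 to compound 4 (1.14 log units; beyond the scatter) and an at least 37-fold lower number from compound 1 to compound 4 (1.57 log units; beyond the scatter), so cyclopentyl sits at the low end of this short series and a similar count of carbons does not make two groups interchangeable at this position.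

The compounds shown cannot say whether the ring itself or the extra carbon drives the step, since a straight pentyl chain would be needed to separate the two, and the true distance below the limit for compound 4 stays unknown. They also leave open whether an amine or a carboxylic acid on this same carbon would give a number nearer that of compound 1, or whether any group here can match hydrogen.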